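Removing the methoxy group from compound 2

This account rests on a few compounds, and the source may have more. Where it says the series, first, only, none or still open, it means among the compounds named here.

Measured so far:
compound 1 `O=C1NCCN1c1ccc(S(=O)(=O)Nc2ccc(F)c(F)c2)cc1`: 350 nM
compound 2 `COc1cccc(NS(=O)(=O)c2ccc(N3CCNC3=O)cc2)c1`: 120 nM

In a functional assay on HT-29 cells (Homo sapiens) for antiproliferative activity, read by sulforhodamine B assay, with a stated time of 48 h (on this read-out lower numbers stand for stronger inhibition and higher numbers for weaker inhibition), compound 2 stands lowest of the two numbers, and its step from compound 1 was a 2.9-fold lower number from compound 1 to compound 2 (0.46 log units; beyond the scatter). Compound 3 `O=C1NCCN1c1ccc(S(=O)(=O)Nc2ccccc2)cc1` differs from compound 2 in one place: hydrogen in place of methoxy on an aromatic carbon. Among the compounds with values here, the only measured step shows that changing the group on the sulfonamide nitrogen shifts the number modestly, so a modest step is expected here too, probably toward a higher number, since compound 2 holds the lowest value at 120 nM. For compound 3 the estimated step is a 2.1-fold higher number from compound 2 to compound 3 (0.32 log units; beyond the scatter), giving an expected value of 250 nM, ranging from 100 nM to 650 nM.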

Compound 3, half-maximal inhibitory concentration: 280 nM
Compound 3: the middle estimate sits 1.1-fold (0.05 log units) below what was measured; the measured number falls inside the stated range.
By their numbers in this assay, from the lowest: compound 2; then compounds 3 and 1 (each within the scatter of the next).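

Taking the methoxy group off in this assay gives a 2.3-fold higher number from compound 2 to compound 3 (0.37 log units; beyond the scatter) and so weakens inhibition, which shows that this group counts for something on the aromatic ring of compound 2. Swapping 3,4-difluorophenyl for phenyl gives a 1.3-fold lower number from compound 1 to compound 3 (0.10 log units; within the scatter) and so leaves no readable difference between these two groups. No measurement here explains the effect of the methoxy group.

Still open, on these data alone, is how a hydroxyl group or an amine would behave in the place of the methoxy group. A longer ether such as ethoxy also remains untested in the compounds shown here.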